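Compound 4: methoxy in place of methylsulfanyl

A few compounds are considered here, and "the series" means these few. Any claim that something is new, unique, unknown or untested is made for them only; others in the source may bear on it.

In a functional assay on P388D1 cells (Mus musculus) for antiproliferative activity, read by MTT assay (a lower number here means a stronger inhibitor, a higher number a weaker inhibitor), compound 1 `O=C1NC(c2ccccc2)CN1S(=O)(=O)c1ccc2c(c1)CCCN2C(=O)C(F)(F)F` gives 4720 nM. Compound 2 `CC1(c2ccccc2)CN(S(=O)(=O)c2ccc3c(c2)CCCN3C(=O)C(F)(F)F)C(=O)N1` reads > 20000 nM, which is a limit and not a number. Among the measured compounds shown here, the only readable step runs an at least 4.2-fold higher number from compound 1 to compound 2 (0.62 log units; beyond the scatter), and it concerns a saturated ring carbon. The next step, a step that the two limits leave unreadable from compound 2 to compound 3, brings in the substituted phenyl group but gives no size. Compound 3 `CSc1ccc(NC(=O)N2CCCc3cc(S(=O)(=O)N4CC(C)(c5ccccc5)NC4=O)ccc32)cc1` stands at > 20000 nM, again a limit. Compound 4 `COc1ccc(NC(=O)N2CCCc3cc(S(=O)(=O)N4CC(C)(c5ccccc5)NC4=O)ccc32)cc1` carries methoxy in place of methylsulfanyl on an aromatic carbon, para to a large group: methoxy in place of methylsulfanyl on an aromatic carbon. For the measured compounds named here, no measured step covers this change, so no step beyond the scatter is expected in this assay. The expected step is a number no higher from compound 3 to compound 4 (the limit leaves the size open). The estimate for compound 4 is 20000 nM, with an expected range of 7000 nM to 40000 nM.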

Compound 4, half-maximal inhibitory concentration: 15900 nM
Compound 4: the middle estimate sits 1.3-fold (0.10 log units) above what was measured, within the range that was stated.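

In this assay compound 4 gives 15900 nM, so a (4-substituted phenyl)amino compound now has a measured number. The exchange on the aromatic carbon reads as an at least 1.2-fold lower number from compound 3 to compound 4 (0.09 log units; that floor lies within the scatter), and the exchange on the carbonyl carbon reads as an at least 1.2-fold lower number from compound 2 to compound 4 (0.09 log units; that floor lies within the scatter). Neither floor establishes a real gain, and the true sizes stay open since compound 2 and compound 3 each carry a limit: the limit of > 20000 nM in this assay, at which 2 of the 4 values shown sit.

As far as these compounds go, whether an amine, a carboxylic acid or ethoxy on this aromatic carbon would give a different number in this assay remains open. Also open, from the compounds shown here alone, is how the (4-methoxyphenyl)amino group reads without the methyl on the saturated ring carbon.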